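A few compounds are considered here, and "the series" means these few. Any claim that something is new, unique, unknown or untested is made for them only; others in the source may bear on it.

Compound 1 `C1=NCC(CC2=Cc3ccccc3CC2)N1` gives, in a functional assay for binding affinity to Norepinephrine transporter (Rattus norvegicus), read by radioligand binding, in the presence of a further agent that is not named here (a higher number here means a weaker inhibitor, a lower number a stronger inhibitor), 50.1 nM. Compound 2 `Clc1cccc2c1C=C(CC1CN=CN1)CC2` carries the change chloro in place of hydrogen on an aromatic carbon and gives in this assay 50.1 nM; the step is no change at the digits printed from compound 1 to compound 2 (within the scatter). Compound 3 `C1=NCC(CC2CCc3ccccc3C2)N1` gives in this assay 100 nM; how its core differs from that of compound 1 is not broken down here, and the two values lie within the scatter of each other. Compound 4 `Clc1cccc2c1CC(CC1CN=CN1)CC2` has not been measured; it differs from compound 3 by chloro in place of hydrogen on an aromatic carbon, the same change made from compound 1 to compound 2, seen twice in this set. Because no change at the digits printed from compound 1 to compound 2 (within the scatter) was flat, the expected step here is no change at the digits printed from compound 3 to compound 4 (within the scatter), a small one. The estimate for compound 4 in this assay is 100 nM, likely between 40 nM and 250 nM.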

Compound 4, inhibition constant: 100 nM
Compound 4: the middle estimate sits on the measured number at the digits printed; low and high end bracket the measured number.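

Chloro in place of hydrogen on an aromatic carbon gives no change at the digits printed from compound 3 to compound 4 (within the scatter) in this assay, so the flat result holds on a second core. The two steps agree when set side by side: the same change on two cores in this assay, no change at the digits printed (within the scatter) from compound 1 to compound 2 and no change at the digits printed (within the scatter) from compound 3 to compound 4, 1.0-fold (0.00 log units) apart, within the scatter of two such steps. This shows that the change carries across these two cores at this one place in this one assay, but it does not show that the same holds on any other core or at any other place on the aromatic ring.

Open, from the compounds shown here alone, is whether a methoxy group or a nitrile in place of the chloro would also leave the number flat. Also open, going by these compounds, is whether the chloro step stays flat with a longer chain in place of the linker.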